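The source may hold more compounds than are shown below. What is called first, only, known or untested is meant among the compounds shown, and "the series" means these compounds.

Compound 3, `Nc1ccc(-c2cc3ccccc3[nH]2)cc1`, stands highest of the three measured compounds in an assay on isolated protein for inhibition of Aromatase (Homo sapiens), read by fluorescence, using NADPH, with a stated time of 30 min, tested at 50 uM (on this read-out higher numbers stand for more inhibition at the one concentration tested (going by the name of the read-out) and lower numbers for less inhibition), giving 46.2%. Compound 1, `Fc1ccc(-c2cc3ccccc3[nH]2)cc1`, gives 21.8%, and compound 2, `CCCCCc1ccc(-c2cc3ccccc3[nH]2)cc1`, gives 0%. The step of a number 24.4 percentage points higher from compound 1 to compound 3 (beyond the scatter) and the step of a number 46.2 percentage points higher from compound 2 to compound 3 (beyond the scatter) both end at compound 3, and the step of a number 21.8 percentage points lower from compound 1 to compound 2 (beyond the scatter) shows that a longer substituent lowered the read-out.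

Compound 4, `CN(C)c1ccc(-c2cc3ccccc3[nH]2)cc1`, differs from compound 3 in one place: dimethylamino in place of amino on an aromatic carbon. Within the data shown here, no measured step replaces amino with dimethylamino, so only an indirect reading is possible. Among the measured compounds shown here, the two steps that install amino are both rises; the one step that enlarges the substituent from fluoro to pentyl is a fall. Taken together they suggest that adding two carbons to the amino group would more likely lower than raise inhibition in this assay, though by less than the pentyl step. Compound 4 is therefore expected to show a modest fall, a number 16.2 percentage points lower from compound 3 to compound 4 (beyond the scatter), to an estimated 30%, within a range from 10% to 50%.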

Compound 4, a percentage reported as inhibition, at one concentration (the size of the read-out at that concentration, not a potency): 0%
Compound 4: the middle estimate sits 30 percentage points above what was measured; measured number outside the range, below it.
By their numbers in this assay, from the lowest: compounds 2 and 4 (each within the scatter of the next); then compound 1; then compound 3.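

Replacing amino with dimethylamino on this aromatic carbon gives a number 46.2 percentage points lower from compound 3 to compound 4 (beyond the scatter) in this assay, so the high reading of compound 3 does not carry over to a nitrogen bearing two methyl groups, and a nitrogen at this place is not enough on its own to keep the read-out. Set against pentyl, dimethylamino shows no change at the digits printed from compound 2 to compound 4 (within the scatter), and set against fluoro it shows a number 21.8 percentage points lower from compound 1 to compound 4 (beyond the scatter), so here the group with the nitrogen falls in with the pentyl compound rather than rising above the fluoro one. Nothing available here gives a reason for this loss.

The compounds shown leave open whether the loss follows the added carbons or the missing hydrogen-bond donor. A methylamino group or a hydroxyl group at this place would bear on that question.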